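The source may report more compounds than this note shows. Statements on the series, on what has been measured and on what is new or still open speak of the compounds shown alone.

Of the compounds shown here, two built on a shared core have been measured in a functional assay on A549 cells (Homo sapiens) for antiproliferative activity, read by MTT assay, with a stated time of 48 h; on this read-out lower numbers stand for stronger inhibition and higher numbers for weaker inhibition. Compound 1 `O=C(Nc1ccc(OC(=O)c2cc3cc([N+](=O)[O-])ccc3s2)cc1)Nc1ccc(Oc2ccccc2)cc1` gives 25200 nM in this assay. Compound 2 `O=C(Nc1ccc(OC(=O)c2ccc(Cl)cc2)cc1)Nc1ccc(Cl)c(C(F)(F)F)c1` gives 6620 nM, the lower of the two numbers, and its gap to compound 1 lies beyond the usual scatter of repeated measurements. Compound 3 `COc1ccc(C(=O)Oc2ccc(NC(=O)Nc3ccc(Cl)c(C(F)(F)F)c3)cc2)cc1` differs from compound 2 in a single place: methoxy in place of chloro on an aromatic carbon. Within the data shown here, no measured pair shows this exchange, so the step is expected to be modest, leaning toward a weaker effect, and its size is estimated as a 1.4-fold higher number from compound 2 to compound 3 (0.13 log units; within the scatter). Compound 3 is therefore expected to give 9000 nM, within a range from 3500 nM to 25000 nM.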

Compound 3, half-maximal inhibitory concentration: 16100 nM
Estimate against measurement, compound 3: 1.8-fold (0.25 log units) below; the measured number falls inside the stated range.
By their numbers in this assay, from the lowest: compound 2; then compounds 3 and 1 (each within the scatter of the next).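

Among these compounds, the exchange of 4-chlorophenyl for 4-methoxyphenyl gives the first step that can be read directly in this assay: it is a 2.4-fold higher number from compound 2 to compound 3 (0.39 log units; beyond the scatter) and shows that the group at this position matters. Of these two groups, chloro goes with the lower number, meaning stronger inhibition. Nothing available explains this difference.

The compounds shown leave open whether a methyl, an amine or a carboxylic acid at this position would give a lower number than chloro. They also leave open whether this exchange would have the same effect elsewhere in the molecule.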